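From dodecyl to tert-butyl on a shared core

The source may report more compounds than this note shows. Statements on the series, on what has been measured and on what is new or still open speak of the compounds shown alone.

In a functional assay on K562 cells (Homo sapiens) for antiproliferative activity, read by MTT assay, with a stated time of 48 h (on this read-out higher numbers stand for weaker inhibition and lower numbers for stronger inhibition), compound 2 (`CCCCCCCCCCCCNc1nc2ccccc2nc1Oc1ccc(C(=O)N[C@@H](C)C(=O)OC)cc1`) gives 26700 nM as its half-maximal inhibitory concentration. Compound 3 (`CCCCCCCCCCCCNc1nc2ccccc2nc1Oc1ccc(C(=O)N[C@H](C(=O)OC)[C@H](C)CC)cc1`) gives 30800 nM on the same read-out, and compound 1 (`COC(=O)[C@H](C)NC(=O)c1ccc(Oc2nc3ccccc3nc2C)cc1`), which carries no dodecyl, gives 45500 nM there. These three values lie within the usual scatter of one another, so compound 2 is not separated from either neighbour.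

Compound 4 (`COC(=O)[C@H](C)NC(=O)c1ccc(Oc2nc3ccccc3nc2NC(C)(C)C)cc1`) has not yet been measured. The difference from compound 2 is tert-butyl in place of dodecyl on a nitrogen on an aromatic ring and it amounts to tert-butyl in place of dodecyl on a nitrogen on an aromatic ring.

For the measured compounds named here, the only measured step is a 1.2-fold higher number from compound 2 to compound 3 (0.06 log units; within the scatter) and it lies at another place in the structure, so it bears on this change only loosely. Compound 1 offers a further indication: at 45500 nM and without dodecyl, it remains within the scatter of compound 2. Going by the values given here, no measured compound carries tert-butyl on that nitrogen, so the basis for the expectation is thin. No step beyond the scatter is therefore expected in this assay for this change. The expected step is a 1.3-fold higher number from compound 2 to compound 4 (0.12 log units; within the scatter) and it stays within the scatter. Compound 4 is estimated at 35000 nM with an expected range from 16000 nM to 75000 nM on this read-out.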

Compound 4, half-maximal inhibitory concentration: 42200 nM
Beside the measured number, compound 4's estimate is 1.2-fold (0.08 log units) below it, within the range that was stated.
By their numbers in this assay, from the lowest: compounds 2, 3, 4 and 1 (each within the scatter of the next).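

In this assay, for the compounds shown here, the first direct step at this position reads a 1.6-fold higher number from compound 2 to compound 4 (0.20 log units; within the scatter), so exchanging dodecyl for tert-butyl on a nitrogen on an aromatic ring, with 12 heavy atoms leaving and 4 entering, does not separate the two compounds. The comparison with the methyl-bearing core reads a 1.1-fold lower number from compound 1 to compound 4 (0.03 log units; within the scatter), which shows that (tert-butyl)amino in place of methyl on an aromatic carbon does not separate those two compounds either, so neither substitution at this place has yet produced a step beyond the scatter. Nothing available explains why these numbers stay so close together.

The compounds shown leave open whether a chain of intermediate length such as hexyl, or a benzyl group, on that nitrogen would give a step beyond the scatter in this assay. They also leave open whether a carboxylic acid in place of the methyl ester would change the reading for this series, since all the changes shown so far remain within the scatter.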